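The source may hold more compounds than are shown below. What is called first, only, known or untested is meant among the compounds shown, and "the series" means these compounds.

Series notes, selenocyanate and diselenide carbamates. Compound 2 `CCCCOC(=O)Nc1ccc([Se]C#N)cc1` gives 12400 nM in a functional assay on PC-3 cells (Homo sapiens) for cytotoxicity, read by MTT assay, with a stated time of 72 h (on this read-out lower numbers stand for stronger inhibition of growth and higher numbers for weaker inhibition of growth), and stands at the top of the three numbers shown, though compound 1 `COc1ccc(OC(=O)Nc2ccc([Se]C#N)cc2)cc1`, with 7500 nM in this assay, lies within the scatter of it. Compound 3 `CCCCCCOC(=O)Nc1ccc([Se][Se]c2ccc(NC(=O)OCCCCCC)cc2)cc1` gives 600 nM in this assay, a gap from compound 2 that is beyond the scatter; compound 3 differs from compound 2 in more than one place, so the two values show only a gap. Compound 4 `CCCCCCOC(=O)Nc1ccc([Se]C#N)cc1` differs from compound 2 by ethyl in place of hydrogen on a saturated chain carbon, four bonds along the chain from an oxygen next to a carbonyl group. Among the measured compounds shown here, no measured pair isolates this change. The expected step of a 2.1-fold lower number from compound 2 to compound 4 (0.32 log units; beyond the scatter) is a moderate lowering of the number, near the edge of the scatter. Compound 4 is thus expected at 6000 nM, within a range from 2500 nM to 15000 nM.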

Compound 4, concentration for 50% growth inhibition: 17300 nM
For compound 4 the middle estimate is 2.9-fold (0.46 log units) below the measured one; measured number outside the range, above it.
By their numbers in this assay, from the lowest: compound 3; then compounds 1, 2 and 4 (each within the scatter of the next, the first and the last beyond it).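

In this assay, ethyl in place of hydrogen at this chain carbon gives a 1.4-fold higher number from compound 2 to compound 4 (0.14 log units; within the scatter) and so moves the selenocyanate carbamates by no readable amount. Compound 3 at 600 nM stays well apart from compound 4, which carries the same longer chain, so chain length at this position does not alone give that low number. Nothing given here explains the flat step. Open, as far as these compounds go, is whether an octyl chain or a terminal amine would shift the number beyond the scatter, and whether a diselenide with the butyl chain would track compound 3.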